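From compound 2 to compound 3: a new ring group

The source may hold more compounds than are shown below. What is called first, only, known or untested is meant among the compounds shown, and "the series" means these compounds.

In a functional assay with Oryctolagus cuniculus as the target (on this read-out higher numbers stand for weaker inhibition and lower numbers for stronger inhibition), compound 1 `COc1ccc(-c2nc(N=C(N)N)sc2-c2ccc(OC)cc2)cc1` gives 31000 nM as its value. Compound 2 `CCOC(=O)/C(C#N)=C/c1nc(-c2ccc(OC)cc2)c(-c2ccc(OC)cc2)s1` gives < 10 nM and this is a limit of the assay, not a number. Compound 2 is therefore known only by that limit.

The next structure is compound 3 `COc1ccc(-c2nc(C3=CCN(C)CC3)sc2-c2ccc(OC)cc2)cc1` and the change is a group of 7 heavy atoms (6 carbon, 1 nitrogen; one six-membered non-aromatic ring with 1 hetero atom) in place of a group of 9 heavy atoms (6 carbon, 1 nitrogen, 2 oxygen; no ring), on an aromatic carbon here. The 2-cyano-2-(ethoxycarbonyl)ethenyl group of compound 2 leaves, and a group with one six-membered non-aromatic ring enters. Among the compounds with values here, one measured step bears on this change: an at least 3100-fold lower number from compound 1 to compound 2 (3.49 log units; beyond the scatter) is large and beyond the scatter, and it concerns the same departing group. The entering group matches neither measured group, so that step gives a direction and no exact size. Given an at least 3100-fold lower number from compound 1 to compound 2 (3.49 log units; beyond the scatter) as the reason, losing this group is expected to bring a higher number in this assay and so weaker inhibition, probably by less than that step. The expected step is an at least 30-fold higher number from compound 2 to compound 3 (1.47 log units; beyond the scatter) as a rough estimate. The estimate for compound 3 is 300 nM with an expected range from 10 nM to 8000 nM as its bounds.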

Compound 3, half-maximal inhibitory concentration: < 10 nM
Compound 3 was reported as a limit; the forecaster's own chance of this, stated with the estimate: 15%; at least 30-fold (1.47 log units) between middle value and limit.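

In this assay, the result for compound 3 shows that reaching the limit at this position does not depend on the 2-cyano-2-(ethoxycarbonyl)ethenyl group: a group with one six-membered non-aromatic ring with 1 hetero atom, on the same aromatic carbon next to the ring nitrogen and next to the ring sulfur, gets there as well. Against the group of compound 1, the new group gives an at least 3100-fold lower number from compound 1 to compound 3 (3.49 log units; beyond the scatter), so two quite different groups now stand apart from compound 1, which is the one compound of the three that goes against this picture. The step between compound 2 and compound 3 cannot be read, because each is known only by a limit and neither has a number: the limit of < 10 nM in this assay, at which 2 of the 3 values shown sit.

The compounds shown therefore give no order between the two groups and do not tell how far either compound lies past the limit of the assay. As far as these compounds go, whether a simple amine, a carboxylic acid or a saturated piperidine ring on this carbon would also reach the limit stays open, and so does which part of the entering group the result depends on.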